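This account rests on a few compounds, and the source may have more. Where it says the series, first, only, none or still open, it means among the compounds named here.

In a functional assay on HeLa cells (Homo sapiens) (on this read-out higher numbers stand for an effect only at larger amounts of compound and lower numbers for an effect already at smaller amounts), three compounds built on a shared core have been measured so far. Compound 1 `CCOC(=O)c1cc(CCl)nn1[C@@H]1O[C@H](COC(C)=O)[C@@H](OC(C)=O)[C@H]1OC(C)=O` gives 32 ug/mL, compound 2 `CCOC(=O)c1cc(CI)nn1[C@@H]1O[C@H](COC(C)=O)[C@@H](OC(C)=O)[C@H]1OC(C)=O` gives 5.5 ug/mL, and compound 3 `CC(=O)OC[C@H]1O[C@@H](n2nc(CCl)cc2C(N)=O)[C@H](OC(C)=O)[C@@H]1OC(C)=O` gives 26 ug/mL. Putting amino in place of ethoxy on a carbonyl carbon produces a 1.2-fold lower number from compound 1 to compound 3 (0.09 log units; within the scatter), so compound 3 stands level with compound 1, and both numbers lie well above that of compound 2.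

Compound 4 `CC(=O)OC[C@H]1O[C@@H](n2nc(CI)cc2C(N)=O)[C@H](OC(C)=O)[C@@H]1OC(C)=O` differs from compound 3 by one change: iodo in place of chloro on a saturated chain carbon bound to an aromatic carbon. The same chloromethyl to iodomethyl exchange has been measured once, as a 5.8-fold lower number from compound 1 to compound 2 (0.76 log units; beyond the scatter). For the measured compounds named here, this single modest step is the only direct precedent, and no measurement yet shows whether it carries over to a compound with amino on the carbonyl carbon. A step of similar size and direction is nevertheless expected, and the estimate is a 5.2-fold lower number from compound 3 to compound 4 (0.72 log units; beyond the scatter). For compound 4 the expected value is 5 ug/mL, with an estimated range from 2.2 ug/mL to 11 ug/mL.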

Compound 4, concentration for half-maximal effect: 1.5 ug/mL
For compound 4 the middle estimate is 3.3-fold (0.52 log units) above the measured one; the whole stated range lies above it.
By their numbers in this assay, from the lowest: compound 4; then compound 2; then compounds 3 and 1 (each within the scatter of the next).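

Iodomethyl in place of chloromethyl lowers the number again when amino sits on the carbonyl carbon (a 17-fold lower number from compound 3 to compound 4 (1.24 log units; beyond the scatter)), so the direction of this change holds on both cores shown. The size of the step, however, differs with the group on the carbonyl carbon: the same change on two cores in this assay, a 5.8-fold lower number (0.76 log units; beyond the scatter) from compound 1 to compound 2 and a 17-fold lower number (1.24 log units; beyond the scatter) from compound 3 to compound 4, 3.0-fold (0.47 log units) apart, beyond the scatter of two such steps. Read the other way, amino in place of ethoxy makes no difference beyond the scatter in the chloromethyl pair but does lower the number in the iodomethyl pair (a 3.7-fold lower number from compound 2 to compound 4 (0.56 log units; beyond the scatter)), so the two changes do not simply add up: the same change on two cores in this assay, a 1.2-fold lower number (0.09 log units; within the scatter) from compound 1 to compound 3 and a 3.7-fold lower number (0.56 log units; beyond the scatter) from compound 2 to compound 4, 3.0-fold (0.47 log units) apart, beyond the scatter of two such steps.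

On these data alone, it remains open whether bromomethyl on the saturated chain carbon would give a number between those of the chloromethyl and iodomethyl compounds. It is also unknown whether a carboxylic acid on the carbonyl carbon would give the larger or the smaller halogen step.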